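The source may hold more compounds than are shown below. What is called first, only, known or untested is meant among the compounds shown, and "the series" means these compounds.

Compound 1 `Fc1ccc(C2(c3ccc(F)cc3)CNC(c3cccc(F)c3)=N2)cc1` is the anchor of this small set. In an assay on LM cells for displacement of a labelled ligand from Neuropeptide Y receptor type 5 (Homo sapiens) (on this read-out lower numbers stand for stronger inhibition and higher numbers for weaker inhibition), compound 1 gives 10 nM, the highest of the three numbers recorded. Compound 2 `O=[N+]([O-])c1cccc(C2=NC(c3ccc(F)cc3)(c3ccc(F)cc3)CN2)c1` gives 4.3 nM in this assay, and compound 3 `O=Cc1cccc(C2=NC(c3ccc(F)cc3)(c3ccc(F)cc3)CN2)c1` gives 8.7 nM. The steps among them are modest at most: a 2.3-fold lower number from compound 1 to compound 2 (0.37 log units; beyond the scatter); a 1.1-fold lower number from compound 1 to compound 3 (0.06 log units; within the scatter); a 2.0-fold higher number from compound 2 to compound 3 (0.31 log units; beyond the scatter).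

Compound 4 `Fc1ccc(C2(c3ccc(F)cc3)CNC(c3ccsc3)=N2)cc1` differs from compound 1 by thiophen-3-yl in place of 3-fluorophenyl on a carbon with a double bond to nitrogen. Among the compounds with values here, none of the measured steps bears directly on this change: each of them exchanges only the substituent on the 3-fluorophenyl group, while that ring itself is kept in compounds 1, 2 and 3. What the three numbers do show is a narrow span across those substituent swaps, with nothing measured on an exchange of the ring for a five-membered one. For compound 4 the expectation is therefore a step in this assay that is within the scatter or only modestly beyond it, with the direction left open and a slightly higher number taken as the more cautious guess. The estimate for compound 4 in this assay is 15 nM, with an expected range from 5 nM to 45 nM. The expected step is a 1.5-fold higher number from compound 1 to compound 4 (0.18 log units; within the scatter).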

Compound 4, half-maximal inhibitory concentration: 93 nM
Beside the measured number, compound 4's estimate is 6.2-fold (0.79 log units) below it, outside the stated range (above it).
By their numbers in this assay, from the lowest: compound 2; then compounds 3 and 1 (each within the scatter of the next); then compound 4.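

In this assay, exchanging the whole aromatic ring on the carbon with a double bond to nitrogen gives a far larger step than the substituent exchanges on that ring among compounds 1, 2 and 3 (a 9.3-fold higher number from compound 1 to compound 4 (0.97 log units; beyond the scatter)). The same exchange reads larger still from the two other phenyl compounds (an 11-fold higher number from compound 3 to compound 4 (1.03 log units; beyond the scatter); a 22-fold higher number from compound 2 to compound 4 (1.34 log units; beyond the scatter)), so within these four compounds the position is more sensitive to the identity of the ring than to the fluoro, nitro or formyl group it carries. No measurement shown explains this loss.

The single exchange from 3-fluorophenyl to thiophen-3-yl changes ring size, introduces sulfur and removes fluorine together, so the compounds shown cannot separate these changes. Also open, as far as these compounds go, is how a plain phenyl group, a furan-3-yl group, or a thiophen-3-yl group carrying a nitro or formyl group would read in this assay, which would show whether the five-membered ring itself or the missing substituent carries the step.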